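This account rests on a few compounds, and the source may have more. Where it says the series, first, only, none or still open, it means among the compounds named here.

Compounds measured so far:

Compound 1, `C=CCn1c(=O)/c(=C\c2cccc(C)c2)[nH]c(=O)/c1=C\c1ccccc1OC`: 16000 nM in a functional assay on MOLT-4 cells (Homo sapiens) for cytotoxicity, read by CCK-8 assay, with a stated time of 72 h; on this read-out lower numbers stand for stronger inhibition and higher numbers for weaker inhibition
Compound 2, `C=CCn1c(=O)/c(=C\c2ccccc2C(F)(F)F)[nH]c(=O)/c1=C\c1ccccc1OC`: 4400 nM
Compound 3, `COc1ccccc1/C=c1/[nH]c(=O)/c(=C\c2cccc(Cl)c2Cl)[nH]c1=O`: "not determined" (no result reported)

Compound 1 stands at the highest of the two numbers obtained in this assay, with compound 2 nearest to it; the step of a 3.6-fold lower number from compound 1 to compound 2 (0.56 log units; beyond the scatter) was made by putting 2-(trifluoromethyl)phenyl in place of 3-methylphenyl on a double-bonded chain carbon bound to an aromatic carbon. Compound 4, `C=CCn1c(=O)/c(=C\c2ccc(Cl)c(Cl)c2)[nH]c(=O)/c1=C\c1ccccc1OC`, has not yet been measured. It differs from compound 1 as follows: 3,4-dichlorophenyl in place of 3-methylphenyl on a double-bonded chain carbon bound to an aromatic carbon. Going by the values given here, the only measured step that bears on this change is the one from compound 1 to compound 2, in which a differently substituted phenyl replaced the same 3-methylphenyl at the same place and brought a modest lowering of the number. On that basis a step of similar size and direction is expected, a 2.7-fold lower number from compound 1 to compound 4 (0.43 log units; beyond the scatter). For compound 4 a value of about 6000 nM is estimated, within a range from 2500 nM to 16000 nM.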

Compound 4, half-maximal inhibitory concentration: "not active" (no number reported)
Nothing numeric was reported for compound 4, and the estimate cannot be compared.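

Going by these compounds alone, compound 4 was reported as not active in this assay, without a number, so no step from compound 1 to compound 4 can be read. Nothing shown here explains this result. The compounds shown leave open how far 3,4-dichlorophenyl separates compound 4 from compound 1 on this read-out.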